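This account rests on a few compounds, and the source may have more. Where it says the series, first, only, none or still open, it means among the compounds named here.

Measured so far:
compound 1 `Cc1ccc2[nH]c(=O)c(CN(Cc3ccc(N(C)C)cc3)Cc3ccc(C(C)(C)C)cc3)cc2c1`, in a toxicity assay on MDCK cells (Canis lupus familiaris) for cytotoxicity, read by crystal violet staining, with a stated time of 48 h (a lower number here means that less compound is tolerated, a higher number that more compound is tolerated), compound 1 gives > 5000 nM
compound 2 `COc1ccc2[nH]c(=O)c(CN(Cc3ccc(N(C)C)cc3)Cc3ccc(C(C)(C)C)cc3)cc2c1`, in this assay compound 2 gives 8500 nM

The value of compound 1 is a limit of the assay, not a number (the limit of > 5000 nM in this assay, at which 1 of the 2 values shown sits). Compound 2 holds the only number shown; the one further value is a limit. The step that the limit leaves unreadable from compound 1 to compound 2 is accordingly unreadable in size. Compound 3 `COc1ccc2[nH]c(=O)c(CN(Cc3ccc(C(C)(C)C)cc3)Cc3ccc(C(F)(F)F)c(Cl)c3)cc2c1` differs from compound 2 by 3-chloro-4-(trifluoromethyl)phenyl in place of 4-(dimethylamino)phenyl on a saturated chain carbon bound to an amine nitrogen. Going by the values given here, no measured step touches this change, so there is no basis for a direction. For compound 3 the expected value is 6000 nM, estimated range 2500 nM to 15000 nM, an expected step of a 1.4-fold lower number from compound 2 to compound 3 (0.15 log units; within the scatter) that stays within the scatter.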

Compound 3, half-maximal cytotoxic concentration: > 10000 nM
Compound 3 ended at the assay's limit; the forecaster's own chance of this, stated with the estimate: 30%; middle value at least 1.6-fold (0.22 log units) from the limit.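

In this assay, 3-chloro-4-(trifluoromethyl)phenyl in place of 4-(dimethylamino)phenyl on a saturated chain carbon bound to an amine nitrogen gives an at least 1.1-fold higher number from compound 2 to compound 3 (0.07 log units; that floor lies within the scatter). Going by these compounds alone, the value of compound 3 is a limit, not a number: the limit of > 10000 nM in this assay, at which 1 of the 3 values shown sits. This is the first readable change at this position, and it shows that tolerance does not depend on keeping 4-(dimethylamino)phenyl there, since the replacement brings no lower number.

Going by these compounds, the true size of the step stays open. So does the outcome with a ring bearing a morpholine or a carboxylic acid at this position.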